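The source may report more compounds than this note shows. Statements on the series, on what has been measured and on what is new or still open speak of the compounds shown alone.

Compound 2, `COc1nc2ccccc2cc1/C=C/c1noc(-c2ccccc2C)n1`, shares its core with compound 1, `COc1nc2ccccc2cc1/C=C/c1noc(-c2ccc(C)cc2)n1`; the two differ only in that compound 2 carries a 2-methylphenyl in place of the 4-methylphenyl of compound 1 on an aromatic carbon. In an ADME assay on HepG2 cells (Homo sapiens) for cytotoxicity, read by sulforhodamine B assay, with a stated time of 48 h (a higher number here means that more compound is tolerated, a lower number that less compound is tolerated), compound 1 reaches only a limit of the assay, > 230000 nM. Compound 2 likewise reaches only a limit, > 230000 nM. The step that the two limits leave unreadable from compound 1 to compound 2 therefore cannot be read in size, since both values sit at the limit of > 230000 nM in this assay, at which 2 of the 2 values shown sit. Compound 3, `COc1ccccc1-c1nc(/C=C/c2cc3ccccc3nc2OC)no1`, differs from compound 2 by methoxy in place of methyl on an aromatic carbon. Going by the values given here, the one measured step bears on this change only loosely: it moved a methyl about the phenyl and left both compounds at the limit. Among the compounds with values here, there is no measured step in which a methoxy enters, so no direction of change can be drawn from the numbers in hand. Compound 3 is therefore expected to sit at the same limit, with a step that the limit leaves unreadable from compound 2 to compound 3 that is expected to stay within the scatter. The estimate for compound 3 in this assay is 300000 nM, expected to fall between 120000 nM and 800000 nM.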

Compound 3, half-maximal cytotoxic concentration: > 220000 nM
Compound 3: no number, only a limit; the forecaster's own chance of this, stated with the estimate: 85%; the middle value does not contradict the limit.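

In this assay compound 3 also reaches only a limit, > 220000 nM. No new step can be read, since the steps to compound 3 from compound 2 and from compound 1 both join limits. The compounds shown leave open at what concentration compound 1, compound 2 or compound 3 would become cytotoxic, and whether methoxy in place of methyl changes that.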